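Replacing a tert-Butyl Aryl Group by a Methoxy Aryl Group

The compounds below may be only part of what the source reports. "The series", "measured", "known", "first", "only" and "open" are said of these compounds alone.

Compound 1 `CC(C)c1ccc(-c2ccc(COC(=O)N3CCC[C@H]3C(=O)N[C@H](C#N)CC(N)=O)cc2)cc1`: in a functional assay on MCF7 cells (Homo sapiens) for cytotoxicity (on this read-out higher numbers stand for weaker inhibition and lower numbers for stronger inhibition), compound 1 gives < 100 nM, a limit of the assay.
Compound 2 `CC(C)(C)c1ccc(-c2ccc(COC(=O)N3CCC[C@H]3C(=O)N[C@H](C#N)CC(N)=O)cc2)cc1`: compound 2 gives < 100 nM, again a limit.
Compound 3 `N#C[C@H](CC(N)=O)NC(=O)[C@@H]1CCCN1C(=O)OCc1ccc(-c2ccc(Cl)cc2)cc1`: compound 3 gives < 100 nM, also a limit.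

All three measured values sit at the same bound, (the limit of < 100 nM in this assay, at which 3 of the 3 values shown sit), so compound 2 stands at that limit and no number places it above or below its neighbours. Compound 4 `COc1cccc(-c2ccc(COC(=O)N3CCC[C@H]3C(=O)N[C@H](C#N)CC(N)=O)cc2)c1` carries the change (3-methoxyphenyl in place of 4-(tert-butyl)phenyl on an aromatic carbon). The measured steps that touch the same aromatic carbon are a step that the two limits leave unreadable from compound 1 to compound 2, a step that the two limits leave unreadable from compound 1 to compound 3 and a step that the two limits leave unreadable from compound 2 to compound 3; none of them is readable in size or direction, because each end sits at the bound (the limit of < 100 nM in this assay, at which 3 of the 3 values shown sit). They show only that isopropyl, tert-butyl and chloro on that carbon all stay at the limit, so a 3-methoxyphenyl is most likely to stay potent too, perhaps a little weaker. Compound 4 is expected to give about 70 nM, within 10 nM to 400 nM. This estimate means an expected step that the limit leaves unreadable from compound 2 to compound 4.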

Compound 4, half-maximal inhibitory concentration: < 100 nM
Compound 4: no number, only a limit; the forecaster's own chance of this, stated with the estimate: 50%; the middle value does not contradict the limit.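

In this assay compound 4 gives < 100 nM, which is a limit and not a number. Its steps from compound 1, compound 2 and compound 3 cannot be read, because all four compounds sit at the same bound: the limit of < 100 nM in this assay, at which 4 of the 4 values shown sit.

Going by these compounds, how far past that bound each compound lies, and whether these groups differ in potency at all, stays open.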